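Dropping One Chlorine from Compound 1

The source may hold more compounds than are shown below. What is called first, only, known or untested is meant among the compounds shown, and "the series" means these compounds.

Three amides built on a shared core have been measured in a functional assay on Daoy cells (Homo sapiens) for antiproliferative activity, read by trypan blue exclusion and crystal violet staining, with a stated time of 72 h; a lower number here means a stronger inhibitor, a higher number a weaker inhibitor. Compound 1 `CCCC(=O)NC(c1ccc(Cl)cc1)c1cc(Cl)c2cccnc2c1O` gives 100 nM. Compound 3 `CCCCC(=O)NC(c1ccc(Cl)c(Cl)c1)c1ccc2cccnc2c1O` gives 100 nM, level with compound 1 at the digits recorded, and these two together hold the lowest of the three numbers. Compound 2 `O=C(NC(c1ccc(Cl)cc1Cl)c1ccc2cccnc2c1O)C1CCCC1` gives 150 nM, the furthest from compound 1, yet this gap lies within the usual scatter of repeated measurements, so no order among the three can be claimed.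

Compound 4 `CCCC(=O)NC(c1ccccc1)c1cc(Cl)c2cccnc2c1O` has not yet been measured. It differs from compound 1 in a single place: hydrogen in place of chloro on an aromatic carbon. Within the data shown here, no pair of measured compounds differs in only one place, so the size of such a step cannot be read from any of them. Starting from compound 1 with 100 nM, the change is expected to give a higher number, by a modest step that just passes beyond the scatter. Compound 4 is therefore estimated at 250 nM, with a range from 100 nM to 700 nM. This corresponds to an expected step of a 2.5-fold higher number from compound 1 to compound 4 (0.40 log units; beyond the scatter).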

Compound 4, half-maximal inhibitory concentration: 110 nM
The estimate for compound 4 lay 2.3-fold (0.36 log units) above the measured number; the measured number falls inside the stated range.
By their numbers in this assay, from the lowest: compounds 1, 3, 4 and 2 (each within the scatter of the next).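

In this assay, among these compounds, the change from 4-chlorophenyl to phenyl gives a 1.1-fold higher number from compound 1 to compound 4 (0.04 log units; within the scatter) and thus provides the first single-place step in this set. Among the compounds shown here, at this aromatic carbon, para to a large group, hydrogen can stand in place of chloro without a change beyond the scatter, at least in this pair, a point that the earlier compounds, which differ in more than one place, could not show. No available evidence gives a reason for this result.

On these data alone, it remains open whether fluoro, methoxy, trifluoromethyl or an amine at this carbon would also stay within the scatter of compound 1. Also open, as far as these compounds go, is whether the same step would hold without the chloro that compound 4 keeps on the shared core, or with a longer chain on the amide.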